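A few compounds are considered here, and "the series" means these few. Any claim that something is new, unique, unknown or untested is made for them only; others in the source may bear on it.

Compound 1 `CCc1cccc(NC(=O)N[C@H](C)c2ccccc2)c1` gives 36% in an ADME assay on the whole organism with Oryza sativa as the target, tested at 10 uM; on this read-out higher numbers stand for a weaker effect at the one concentration tested and lower numbers for a stronger effect.
Compound 2 `CC(C)c1ccc(NC(=O)N[C@H](C)c2ccccc2)cc1` gives 49% in this assay.
Compound 3 `CC(C)c1ccc(NC(=O)N[C@@H](C)c2ccccc2)cc1` gives 86% in this assay.

Compound 3 stands highest of the three numbers in this assay, with compound 2 nearest and compound 1 furthest off. The only step between two of these compounds, a number 37 percentage points higher from compound 2 to compound 3 (beyond the scatter), rests on the fact that compounds 2 and 3 differ only in the configuration as drawn and leaves every substituent untouched. For the measured compounds named here, compound 4 `CCOC(=O)c1ccc(NC(=O)N[C@@H](C)c2ccccc2)cc1` is the next structure. ethoxycarbonyl in place of isopropyl on an aromatic carbon No measured step changes the group on that aromatic carbon, so the measured steps give no direct guide to this change, and the estimate is kept near compound 3 with a wide range. Compound 4 is expected to give 78%, between 45% and 95%. The expected step is a number 8 percentage points lower from compound 3 to compound 4 (within the scatter), within the scatter.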

Compound 4, a percentage reported as activity, at one concentration (the size of the read-out at that concentration, not a potency): 92%
Compound 4: the middle estimate sits 14 percentage points below what was measured; the measured number falls inside the stated range.
By their numbers in this assay, from the lowest: compound 1; then compound 2; then compounds 3 and 4 (each within the scatter of the next).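

For the compounds shown here, replacing isopropyl with ethoxycarbonyl on an aromatic carbon, para to a large group, gives a number 6 percentage points higher from compound 3 to compound 4 (within the scatter) in this assay, the first measured change at this position. In the configuration drawn for compound 3, the read-out therefore does not separate the two groups, even though ethoxycarbonyl brings oxygen atoms and hydrogen-bond acceptors that isopropyl lacks. Nothing in the data shown bears on why the two groups read alike.

As far as these compounds go, the configuration step is known only with isopropyl, and whether it holds with ethoxycarbonyl remains open. Also open, from the compounds shown here alone, is what an amine or a carboxylic acid on that aromatic carbon would give.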